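A few compounds are considered here, and "the series" means these few. Any claim that something is new, unique, unknown or untested is made for them only; others in the source may bear on it.

Measured so far in a functional assay on K562 cells (Homo sapiens) for inhibition, with a stated time of 72 h; a higher number here means a weaker inhibitor, a lower number a stronger inhibitor:
- compound 1 `NC1CCC(Nc2nc(NCc3ccc(-c4ccco4)cc3)c3ncn(C4CCCC4)c3n2)CC1`: 96 nM
- compound 2 `CC(C)(O)CNc1nc(NCc2ccc(-c3ccco3)cc2)c2ncn(C3CCCC3)c2n1`: 16800 nM
- compound 3 `CC(C)(O)CNc1nc(NCc2ccc(-c3ccco3)nc2)c2ncn(C3CCCC3)c2n1`: 1430 nM

Compound 1 has the lowest number of these three, so it is the best measured inhibitor in this assay. Compound 4 `Nc1ccccc1CNc1nc(NC2CCC(N)CC2)nc2c1ncn2C1CCCC1` has not been measured yet. It differs from compound 1 by one change: 2-aminophenyl in place of 4-(furan-2-yl)phenyl on a saturated chain carbon bound to a nitrogen on an aromatic ring. The 4-aminocyclohexyl group stays in place.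

For the measured compounds named here, two measured steps bear on this, though neither makes the same change. The first is a 180-fold higher number from compound 1 to compound 2 (2.24 log units; beyond the scatter), which replaces 4-aminocyclohexyl. Compound 4 keeps that group, so this large step gives no reason to expect a number as high as that of compound 2. The second is a 12-fold lower number from compound 2 to compound 3 (1.07 log units; beyond the scatter), which is also large. It shows that the group on the saturated chain carbon can matter a great deal, but it swaps a different group and was seen with a different partner group on the core.

Going by the values given here, no measured compound lacks the furan ring, so the direction is a judgment, and compound 1 already has the lowest number. The expected step is moderate and upward: a 4.7-fold higher number from compound 1 to compound 4 (0.67 log units; beyond the scatter). Compound 4 is estimated at 450 nM, with an expected range of 90 nM to 2500 nM.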

Compound 4, half-maximal inhibitory concentration: 4040 nM
For compound 4 the middle estimate is 9.0-fold (0.95 log units) below the measured one; measured number outside the range, above it.
By their numbers in this assay, from the lowest: compound 1; then compound 3; then compound 4; then compound 2.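

In this assay, the group on the saturated chain carbon can move the number a long way even with the 4-aminocyclohexyl group kept in place: 2-aminophenyl in place of 4-(furan-2-yl)phenyl gives a 42-fold higher number from compound 1 to compound 4 (1.62 log units; beyond the scatter) and is a large step. For the compounds shown here, the only earlier step at this place, a 12-fold lower number from compound 2 to compound 3 (1.07 log units; beyond the scatter), kept a furan ring and was seen with 2-hydroxy-2-methylpropyl as the partner group, whereas this is the first step that removes the furan ring, and it shows that 4-aminocyclohexyl alone does not hold the number near that of compound 1. No measurement on these compounds accounts for the rise, so the step gives its size and no explanation.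

This single change removes a ring and adds an amine together, so the compounds shown cannot tell the two apart, and a plain phenyl group at this place would differ from compound 4 only by the amine. Also open, as far as these compounds go, is whether 6-(furan-2-yl)pyridin-3-yl would lower the number with 4-aminocyclohexyl as its partner, as it did with 2-hydroxy-2-methylpropyl.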